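The source may report more compounds than this note shows. Statements on the series, on what has been measured and on what is new or still open speak of the compounds shown alone.

Compounds measured so far:

- compound 1 `CCCN(CCC)Cc1ccc(Cl)c(-c2ccccc2OC)c1`: in an assay on isolated protein for binding affinity to 5-hydroxytryptamine receptor 1D (Homo sapiens) (a lower number here means a stronger inhibitor, a higher number a weaker inhibitor), compound 1 gives > 10000 nM, which is a limit of the assay and not a number.
- compound 2 `CCNCc1ccc(Cl)c(-c2ccccc2OC)c1`: in this assay compound 2 gives 220 nM.
- compound 3 `COc1ccccc1-c1cc(CN(C)C)ccc1Cl`: in this assay compound 3 gives 1300 nM.

Compound 3 therefore holds the highest of the two numbers in hand; its nearest neighbour is compound 2, with a 5.9-fold higher number from compound 2 to compound 3 (0.77 log units; beyond the scatter). Compound 1 sits at the limit (the limit of > 10000 nM in this assay, at which 1 of the 3 values shown sits), so its distance from compound 3 is known only as an at least 7.6-fold lower number from compound 1 to compound 3 (0.88 log units; beyond the scatter).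

The next compound, compound 4 `CCCCNCc1ccc(Cl)c(-c2ccccc2OC)c1`, differs from compound 3 in one place: butylamino in place of dimethylamino on a saturated chain carbon bound to an aromatic carbon. For the measured compounds named here, the steps that bear on it are a 5.9-fold higher number from compound 2 to compound 3 (0.77 log units; beyond the scatter), where a secondary ethylamino gave the lower number, and an at least 45-fold lower number from compound 1 to compound 2 (1.65 log units; beyond the scatter) together with an at least 7.6-fold lower number from compound 1 to compound 3 (0.88 log units; beyond the scatter), where the dipropylamino of compound 1 fell at the limit. A secondary amine is retained in compound 4, but with a longer chain than in compound 2, so a lower number than compound 3 is expected, of roughly the size of the reversed step from compound 2, with some allowance for the longer chain. The estimate for compound 4 in this assay is 400 nM, between 100 nM and 1600 nM, a step of a 3.3-fold lower number from compound 3 to compound 4 (0.51 log units; beyond the scatter) expected from compound 3.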

Compound 4, inhibition constant: 2000 nM
Compound 4: the middle estimate sits 5.0-fold (0.70 log units) below what was measured, and the stated range ends below it.
By their numbers in this assay, from the lowest: compound 2; then compounds 3 and 4 (each within the scatter of the next). At a limit, above all of these: compound 1.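

Keeping a secondary amine does not by itself secure the lower number: butylamino and dimethylamino cannot be told apart, with a 1.5-fold higher number from compound 3 to compound 4 (0.19 log units; within the scatter). The length of the chain on the secondary amine does count, as a 9.1-fold higher number from compound 2 to compound 4 (0.96 log units; beyond the scatter) shows, so among the secondary amines shown, the ethylamino of compound 2 holds the advantage and the butylamino of compound 4 loses it. Against dipropylamino the step is only a bound, an at least 5.0-fold lower number from compound 1 to compound 4 (0.69 log units; beyond the scatter), since that end of the series is a limit and not a number: the limit of > 10000 nM in this assay, at which 1 of the 4 values shown sits.

Still open, as far as these compounds go, is how the number moves with a methylamino, a propylamino or a primary amine on the same chain carbon. Also open, from the compounds shown here alone, is whether a cyclic amine such as pyrrolidine would track the secondary or the tertiary amines.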